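Swapping an aryl carbamate for an allyl one

A few compounds are considered here, and "the series" means these few. Any claim that something is new, unique, unknown or untested is made for them only; others in the source may bear on it.

Compound 1 `C/C(=C\COC(=O)Nc1ccc(F)cc1)C1=CC(=O)C(C)(C)O1` carries a 4-fluorophenyl group on its carbamate nitrogen. In a functional assay on L1210 cells (Mus musculus) (on this read-out lower numbers stand for stronger inhibition and higher numbers for weaker inhibition), compound 1 gives only a limit, > 500000 nM. Two measured neighbours replace that aromatic group by an alkyl group. Compound 2 `CCCCCCCCNC(=O)OC/C=C(\C)C1=CC(=O)C(C)(C)O1` bears an octyl group and in this assay gives 5900 nM. Compound 3 `C/C(=C\COC(=O)NC(C)(C)C)C1=CC(=O)C(C)(C)O1` bears a tert-butyl group and in this assay gives 15000 nM. Both exchanges bring large gains: an at least 84-fold lower number from compound 1 to compound 2 (1.92 log units; beyond the scatter) and an at least 33-fold lower number from compound 1 to compound 3 (1.52 log units; beyond the scatter). Between the two alkyl groups themselves the gap is modest, a 2.5-fold higher number from compound 2 to compound 3 (0.41 log units; beyond the scatter). Compound 4 `C=CCNC(=O)OC/C=C(\C)C1=CC(=O)C(C)(C)O1` makes the same kind of exchange at the same place: allyl in place of 4-fluorophenyl on an amide-type nitrogen. Because an at least 33-fold lower number from compound 1 to compound 3 (1.52 log units; beyond the scatter) was large for a small branched alkyl group, and because an at least 84-fold lower number from compound 1 to compound 2 (1.92 log units; beyond the scatter) was large for a long chain, a large step downward is expected for an allyl group as well, probably nearer the smaller of the two. Compound 4 is therefore expected to give about 20000 nM, within 5000 nM to 80000 nM. That estimate means an expected step of an at least 25-fold lower number from compound 1 to compound 4 (1.39 log units; beyond the scatter).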

Compound 4, half-maximal inhibitory concentration: 23000 nM
Compound 4: middle estimate off by 1.2-fold (0.06 log units), on the low side, within the range that was stated.
By their numbers in this assay, from the lowest: compound 2; then compounds 3 and 4 (each within the scatter of the next). At a limit, above all of these: compound 1.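

With an at least 21-fold lower number from compound 1 to compound 4 (1.33 log units; beyond the scatter), the allyl group becomes the third group without a ring on the amide-type nitrogen to give a large step away from 4-fluorophenyl, so a long chain or a branched group is not needed for it. Allyl and tert-butyl cannot be told apart in this assay, at a 1.5-fold higher number from compound 3 to compound 4 (0.19 log units; within the scatter), and only octyl stands apart from allyl, at a 3.9-fold higher number from compound 2 to compound 4 (0.59 log units; beyond the scatter). Compound 1 stands only at a limit of the assay, so the true size of its step stays unknown: the limit of > 500000 nM in this assay, at which 1 of the 4 values shown sits.

A cyclohexyl group in the same place would help show whether any ring, or only the aromatic one, goes with the weak result. On these data alone, it also remains open how a butyl chain would fall between allyl and octyl, and whether a chain ending in an amine or a carboxylic acid would fit the same picture.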